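Cytotoxicity notes: benzyl variation on the shared core

The source may report more compounds than this note shows. Statements on the series, on what has been measured and on what is new or still open speak of the compounds shown alone.

The series shares one core, shown in compound 1 `COC(=O)c1ccc(NCc2cncn2Cc2ccccc2Br)cc1-c1ccccc1`. For the measured compounds named here, in a toxicity assay on NIH3T3 cells (Mus musculus) for cytotoxicity, read by resazurin assay (on this read-out lower numbers stand for an effect already at smaller amounts and higher numbers for an effect only at larger amounts of compound), compound 1 gives 10000 nM, the only full number among the three values at hand. Compound 2 `CC(C)OC(=O)c1ccc(NCc2cncn2Cc2ccc(-c3ccccc3)cc2)cc1-c1ccccc1` carries an isopropyl ester on the core and a biphenyl group on the saturated chain carbon bound to an aromatic nitrogen. In this assay compound 2 reaches only a limit, > 10000 nM, which is the limit of > 10000 nM in this assay, at which 1 of the 3 values shown sits. Compound 3 `Nc1cc(-c2ccccc2)ccc1Cn1cncc1CNc1ccc(-c2cncs2)c(-c2ccccc2)c1`, with a thiazole and an aminophenyl group, likewise gives only a limit in this assay, > 1000 nM, which is the limit of > 1000 nM in this assay, at which 1 of the 3 values shown sits. So compound 1 stands at the lone number, with the two other values at or beyond limits that do not allow an ordering against it.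

Compound 4 `COC(=O)c1ccc(NCc2cncn2Cc2cccc(C(C)(C)C)c2)cc1-c1ccccc1` has not yet been measured in this assay. It differs from compound 1 as follows: 3-(tert-butyl)phenyl in place of 2-bromophenyl on a saturated chain carbon bound to an aromatic nitrogen. Going by the values given here, no measured step between two compounds differing in one place exists here, so the size of the change cannot be read from the data. The expectation is a step from compound 1 to compound 4 of a 1.2-fold higher number from compound 1 to compound 4 (0.08 log units; within the scatter) in this assay, that is, none beyond the scatter. Compound 4 is therefore estimated at 12000 nM, within 4000 nM to 40000 nM, with a fair chance that this assay reports only a limit.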

Compound 4, half-maximal effective concentration: > 1000 nM
Compound 4 gave a limit, no number; the forecaster's own chance of this, stated with the estimate: 60%; the middle value is on the limit's open side.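

Compound 4 gives only a limit in this assay, > 1000 nM, so no new step against compound 1 can be read: the limit of > 1000 nM in this assay, at which 2 of the 4 values shown sit.

The compounds shown leave open whether 3-(tert-butyl)phenyl in place of 2-bromophenyl on a saturated chain carbon bound to an aromatic nitrogen shifts the value in this assay at all, and in which direction.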